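This account rests on a few compounds, and the source may have more. Where it says the series, first, only, none or still open, it means among the compounds named here.

Measured so far:
compound 1 `COC(=O)c1ccc(NCc2cncn2Cc2ccccc2C)cc1-c1ccccc1` — 10000 nM
compound 2 `CN(C)C(=O)c1ccc(NCc2cncn2Cc2ccc(-c3ccccc3)cc2)cc1-c1ccccc1` — > 1000 nM

Among the compounds with values here, in a toxicity assay on NIH3T3 cells (Mus musculus) for cytotoxicity, read by resazurin assay (a lower number here means that less compound is needed, a higher number that more compound is needed for the effect), compound 1 gives 10000 nM, the only actual number among the two measured compounds. For compound 2 the result in this assay is a limit, > 1000 nM, which is the limit of > 1000 nM in this assay, at which 1 of the 2 values shown sits, and not a number. Compound 3 `COC(=O)c1ccc(NCc2cncn2Cc2ccccc2[N+](=O)[O-])cc1-c1ccccc1` is not yet measured; it differs from compound 1 by nitro in place of methyl on an aromatic carbon. Within the data shown here, no measured pair differs in just one place, so no step size is known from the data. The change from compound 1 to compound 3 is expected to stay within the usual scatter, a step of no change at the digits printed from compound 1 to compound 3 (within the scatter). Compound 3 is estimated at 10000 nM, within 3000 nM to 30000 nM.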

Compound 3, half-maximal effective concentration: 10000 nM
For compound 3 middle estimate and measured number coincide at the digits printed; measured number inside the range.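

In this assay, within the data shown here, the data now hold a first step between two compounds that differ in one place: no change at the digits printed from compound 1 to compound 3 (within the scatter). On this aromatic carbon, ortho to a large group, going from 2-methylbenzyl to 2-nitrobenzyl therefore leaves the cytotoxicity reading where it was. Nothing measured here gives a reason for this. As far as these compounds go, whether an amine or a carboxylic acid on the same carbon would read the same remains open. So does whether nitro in place of methyl would give the same result on another aromatic carbon.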